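The compounds below may be only part of what the source reports. "The series", "measured", "known", "first", "only" and "open" are said of these compounds alone.

Measured in a functional assay on HT-29 cells (Homo sapiens) for antiproliferative activity, read by sulforhodamine B assay, with a stated time of 48 h; a lower number here means a stronger inhibitor, a higher number a weaker inhibitor:
- compound 1 `Cc1ccc(NS(=O)(=O)c2ccc(N3CCNC3=O)cc2)cc1`: 480 nM
- compound 2 `CCCCc1ccc(NS(=O)(=O)c2ccc(N3CCNC3=O)cc2)cc1`: 610 nM
- compound 3 `O=C1NCCN1c1ccc(S(=O)(=O)Nc2ccc(Br)cc2)cc1`: 300 nM

Compound 3 shares the low end of these numbers with compound 1, as the gap is small: a 1.6-fold lower number from compound 1 to compound 3 (0.20 log units; within the scatter). The gap on the other side is a 2.0-fold lower number from compound 2 to compound 3 (0.31 log units; beyond the scatter).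

Next is compound 4 `CCCCCCOc1ccc(NS(=O)(=O)c2ccc(N3CCNC3=O)cc2)cc1`, with hexyloxy in place of bromo on an aromatic carbon, para to a large group: hexyloxy in place of bromo on an aromatic carbon.

Among the compounds with values here, two measured steps touch this position on the same ring. The first, a 1.3-fold higher number from compound 1 to compound 2 (0.10 log units; within the scatter), shows that extending the alkyl group there changes little. Of the groups measured at this position, butyl is the closest to hexyloxy, so the more useful guide is a 2.0-fold lower number from compound 2 to compound 3 (0.31 log units; beyond the scatter), read in reverse. Within the data shown here, no measured compound carries an oxygen at this position, and none carries a chain as long as hexyloxy, so the guide is an extrapolation and the range has to stay wide.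

A modest loss of potency in this assay is therefore expected, somewhat larger than the step from bromo to butyl: a 2.5-fold higher number from compound 3 to compound 4 (0.40 log units; beyond the scatter). The estimated value for compound 4 is 750 nM, with an expected range from 300 nM to 2200 nM.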

Compound 4, half-maximal inhibitory concentration: > 1000 nM
Compound 4 ended at the assay's limit (the forecaster's own chance of this, stated with the estimate: 5%); at least 1.3-fold (0.12 log units) between middle value and limit.
By their numbers in this assay, from the lowest: compounds 3, 1 and 2 (each within the scatter of the next, the first and the last beyond it). At a limit, above all of these: compound 4.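

In this assay, within the data shown here, compound 4 gives > 1000 nM, which is a limit of the assay and not a number, and the only such result in this set: the limit of > 1000 nM in this assay, at which 1 of the 4 values shown sits. Hexyloxy on this aromatic carbon, para to a large group, is the first change here to move the number clearly away from both smaller groups, with an at least 3.3-fold higher number from compound 3 to compound 4 (0.52 log units; beyond the scatter) for the change from bromo and an at least 2.0-fold higher number from compound 1 to compound 4 (0.31 log units; beyond the scatter) for the change from methyl, while the earlier change from methyl to butyl stayed within the scatter. Against butyl the reading is weaker, as an at least 1.6-fold higher number from compound 2 to compound 4 (0.21 log units; that floor lies within the scatter) gives only a floor, so the position is shown to respond to hexyloxy, but the true size of the gap to butyl stays undetermined.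

The compounds shown leave open whether the ether oxygen or the length of the chain goes with this change, a question that hexyl and methoxy on the same carbon would help to separate. Also open, as far as these compounds go, are how far past the limit compound 4 lies and how an amine or a carboxylic acid at this place would read.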